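Chloro additions on the benzylidene ring of enone growth inhibitors

The source may hold more compounds than are shown below. What is called first, only, known or untested is meant among the compounds shown, and "the series" means these compounds.

Compound 1 `O=C(/C(=C/c1ccccc1)CCl)c1ccccc1`: 18000 nM
Compound 2 `O=C(/C(=C/c1ccc(Cl)cc1)CCl)c1ccccc1`: 19000 nM
Compound 3 `CC(=O)OC/C(=C\c1ccc(Cl)cc1)C(=O)c1ccc(Cl)cc1`: 18000 nM

All three measured compounds were tested in a functional assay on WiDr cells (Homo sapiens) for inhibition, read by sulforhodamine B assay, with a stated time of 48 h; a higher number here means a weaker inhibitor of growth, a lower number a stronger inhibitor of growth. Compound 2 is compound 1 carrying chloro in place of hydrogen on an aromatic carbon, para to a large group (chloro in place of hydrogen on an aromatic carbon), and the step is a 1.1-fold higher number from compound 1 to compound 2 (0.02 log units; within the scatter). Compound 3 has a different core from compound 1; the difference between the two cores is not broken down here. In this assay compound 3 sits level with compound 1 and near compound 2, all within the scatter of one another.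

Compound 4 `CC(=O)OC/C(=C\c1ccc(Cl)cc1Cl)C(=O)c1ccc(Cl)cc1` is not yet measured. It differs from compound 3 by chloro in place of hydrogen on an aromatic carbon. This is the same kind of change as that from compound 1 to compound 2, but the place differs: here the chloro sits ortho to a large group and meta to a chloro group, rather than para to a large group. Among the compounds with values here, the only precedent is the flat step a 1.1-fold higher number from compound 1 to compound 2 (0.02 log units; within the scatter), so the expected step is no change at the digits printed from compound 3 to compound 4 (within the scatter), resting on that precedent alone. Compound 4 is estimated at 18000 nM, between 9000 nM and 36000 nM.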

Compound 4, concentration for 50% growth inhibition: 8100 nM
Compound 4: middle estimate off by 2.2-fold (0.35 log units), on the high side, outside the stated range (below it).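

In this assay, the added chloro that turns 4-chlorophenyl into 2,4-dichlorophenyl gives a 2.2-fold lower number from compound 3 to compound 4 (0.35 log units; beyond the scatter), a modest step. Set beside the earlier chloro addition on the core of compound 1, this step cannot be told apart from it: the same change on two cores in this assay, a 1.1-fold higher number (0.02 log units; within the scatter) from compound 1 to compound 2 and a 2.2-fold lower number (0.35 log units; beyond the scatter) from compound 3 to compound 4, 2.3-fold (0.37 log units) apart, within the scatter of two such steps. Within the data shown here, this gives no sign that the change behaves differently on the two cores, but it does not show that the change carries across them either, as only one step is available on each core, and the chloro sits at a different place in each pair, so core and place cannot be separated.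

The compounds shown leave open how a 2,4-dichlorophenyl ring would read on the core of compound 1, which would separate the core from the place of the chloro. They also leave open whether a fluoro, a methoxy or an amine in place of the added chloro would give a step of similar size on either core.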